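The source may report more compounds than this note shows. Statements on the series, on what has been measured and on what is new or still open speak of the compounds shown alone.

Measured so far:
compound 1, `COC(=O)C1=C(c2ccc(OC(F)(F)F)cc2)CCC1`, 2650000 nM
compound 2, `COC(=O)C1=C(c2cccc(Cl)c2)CCCCC1`, 22000 nM
compound 3, `COC(=O)[C@@H]1CCCC[C@@H]1c1ccc(C(C)(C)C)cc1`, 766000 nM

In an assay on COS-1 cells for displacement of a labelled ligand from sodium-dependent dopamine transporter (Homo sapiens) (a lower number here means a stronger inhibitor, a higher number a weaker inhibitor), compound 3 stands second highest of the three numbers, the gap to compound 1 and the larger gap to compound 2 both beyond the scatter. Compound 2 and compound 1 differ from compound 3 in more than one place, so no single step can be read from them.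

Compound 4, `COC(=O)[C@@H]1CCCC[C@@H]1c1ccc(C(F)(F)F)cc1`, differs from compound 3 only in the aryl substituent: trifluoromethyl in place of tert-butyl on an aromatic carbon. Within the data shown here, with no step of one change measured, there is no basis to expect a change beyond the scatter, and the expected step of a 1.3-fold lower number from compound 3 to compound 4 (0.11 log units; within the scatter) is set close to none. Compound 4 is therefore estimated at 600000 nM, within a range from 120000 nM to 3000000 nM.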

Compound 4, inhibition constant: 222000 nM
The estimate for compound 4 lay 2.7-fold (0.43 log units) above the measured number; low and high end bracket the measured number.
By their numbers in this assay, from the lowest: compound 2; then compound 4; then compound 3; then compound 1.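

In this assay, among these compounds, trifluoromethyl in place of tert-butyl on the aromatic carbon gives a 3.5-fold lower number from compound 3 to compound 4 (0.54 log units; beyond the scatter), a modest step but beyond the scatter, and the first single change that can be read. The two groups have the same heavy-atom count and neither has a hydrogen-bond donor or acceptor, yet the swap still moves the number, so the substituent at this place matters. Nothing measured here explains the shift. From the compounds shown here alone, how a methoxy group or a plain hydrogen at this place would compare remains open, as does the effect of an amine on the shared core.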